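Methoxy to butoxy: notes ahead of compound 3

The compounds below may be only part of what the source reports. "The series", "measured", "known", "first", "only" and "open" are said of these compounds alone.

Measured so far:
compound 1 `COc1cc(C(N)=O)nn1-c1ccccc1` — 34.3%
compound 2 `COc1cc(C(=O)N2CCCCC2)nn1-c1ccccc1` — 28.2%

In a functional assay on the whole organism (strain Wistar) for inhibition, with Rattus norvegicus as the target, read by paw edema, with stated times of 30 min and 3 h, at a dose of 100 mg/kg by the oral route (a higher number here means more inhibition at the dose given (going by the name of the read-out), a lower number less inhibition), compound 1 gives 34.3%. Compound 2, which carries piperidin-1-yl in place of amino on the carbonyl carbon, gives 28.2%. For the measured compounds named here, the one measured step is a number 6.1 percentage points lower from compound 1 to compound 2 (within the scatter), so the two numbers are not separated; compound 1 stands at one of two numbers, with compound 2 within the scatter of it.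

Compound 3 `CCCCOc1cc(C(N)=O)nn1-c1ccccc1` differs from compound 1 by propyl in place of hydrogen on a saturated chain carbon bound to an oxygen on an aromatic ring. Going by the values given here, no measured step touches the chain on the ring oxygen: the single step in hand, a number 6.1 percentage points lower from compound 1 to compound 2 (within the scatter), concerns the carbonyl substituent and is itself within the scatter. Nothing in the two values therefore points to a direction for the methoxy-to-butoxy change, and the expectation is a step no larger than the scatter, a number 4.3 percentage points lower from compound 1 to compound 3 (within the scatter).

Compound 3 is estimated at 30% in this assay, with a range of 10% to 50%, centred near compound 1 because of 34.3%.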

Compound 3, a percentage reported as inhibition, in the whole organism at one dose (the size of the read-out at that dose, not a potency): 26.5%
Estimate against measurement, compound 3: 3.5 percentage points above, within the range that was stated.
By their numbers in this assay, from the lowest: compounds 3, 2 and 1 (each within the scatter of the next).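

In this assay, for the compounds shown here, butoxy in place of methoxy on the ring oxygen gives a number 7.8 percentage points lower from compound 1 to compound 3 (within the scatter), the first measured step at this position. Adding propyl on the saturated chain carbon bound to an oxygen on an aromatic ring therefore does not separate compound 3 from compound 1 at this single oral dose, although the amino group on the carbonyl carbon is the same in both. No independent measurement on these compounds is available to account for this result.

As far as these compounds go, a single step cannot show how values run along the chain, so it remains open whether ethoxy, propoxy, a longer chain such as hexyloxy, or a butoxy chain ending in an amine or a carboxylic acid would stand apart from compound 1 in this assay. From the compounds shown here alone, it also remains open how butoxy behaves when paired with piperidin-1-yl on the carbonyl carbon, and whether the same step would hold at other doses.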